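The source may report more compounds than this note shows. Statements on the series, on what has been measured and on what is new or still open speak of the compounds shown alone.

In an ADME assay on HepG2 cells (Homo sapiens) for cytotoxicity, read by fluorescence and resazurin assay, with a stated time of 24 h (a lower number here means that less compound is tolerated, a higher number that more compound is tolerated), two compounds built on the shared core have been measured so far. Compound 1 `COc1ccccc1-c1nnc(SC2=CS(=O)(=O)c3ccccc32)o1` gives 16000 nM and compound 2 `Cc1ccc(-c2nnc(SC3=CS(=O)(=O)c4ccccc43)o2)cc1` gives 31000 nM in this read-out. These two numbers lie within the scatter of each other, so the data do not separate compound 2 from compound 1. Compound 3 `O=S1(=O)C=C(Sc2nnc(-c3cccc(Cl)c3)o2)c2ccccc21` keeps the shared core and differs from compound 2 as follows: 3-chlorophenyl in place of 4-methylphenyl on an aromatic carbon and so it has 3-chlorophenyl in place of 4-methylphenyl on an aromatic carbon. Among the measured compounds shown here, only one measured step bears on this change. It is a 1.9-fold higher number from compound 1 to compound 2 (0.29 log units; within the scatter) and it also exchanges one substituted phenyl group for another on an aromatic carbon. For the measured compounds named here, that step stayed within the scatter, although no compound carrying 3-chlorophenyl has been measured. No step beyond the scatter is therefore expected in this assay for this change. The expected step is a 1.2-fold lower number from compound 2 to compound 3 (0.09 log units; within the scatter) and it would remain within the scatter. For compound 3 the estimate is 25000 nM with an expected range from 10000 nM to 60000 nM in this read-out.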

Compound 3, half-maximal cytotoxic concentration: 27000 nM
For compound 3 the middle estimate is 1.1-fold (0.03 log units) below the measured one, within the range that was stated.
By their numbers in this assay, from the lowest: compounds 1, 3 and 2 (each within the scatter of the next).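

In this assay, putting 3-chlorophenyl in place of 4-methylphenyl on the aromatic carbon of the five-membered ring gives a 1.1-fold lower number from compound 2 to compound 3 (0.06 log units; within the scatter) and, in place of 2-methoxyphenyl at the same carbon, gives a 1.7-fold higher number from compound 1 to compound 3 (0.23 log units; within the scatter), so neither exchange leaves the scatter. Among the compounds shown here, the earlier pair showed this for only two groups, both without chlorine, whereas this position has now carried three substituted phenyl groups, including one with a chlorine atom, and the assay separates none of them from the others. Nothing at hand explains why these exchanges leave the read-out within the scatter.

Going by these compounds, all three compounds keep a phenyl ring at this carbon, so it remains open whether an amine, a carboxylic acid or a longer chain in its place would give a step beyond the scatter. On these data alone, it is also open whether the same exchanges would stay within the scatter if another part of the shared core were changed.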